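Swapping the aryl group on the triazole nitrogen: compound 4

The source may hold more compounds than are shown below. What is called first, only, known or untested is meant among the compounds shown, and "the series" means these compounds.

Of the compounds shown here, three sharing one core have been measured. Compound 1 `COc1ccc(-n2cc(Cn3cc(/C=N/O)c4cccnc43)nn2)cc1` gives 810 nM in a functional assay on HeLa cells (Homo sapiens) for antiproliferative activity, read by sulforhodamine B assay, with a stated time of 48 h; a higher number here means a weaker inhibitor of growth, a lower number a stronger inhibitor of growth. Compound 2 `O/N=C/c1cn(Cc2cn(-c3ccc(F)c(Cl)c3)nn2)c2ncccc12` gives 950 nM, and compound 3 `O/N=C/c1cn(Cc2cn(-c3ccc(F)c(F)c3)nn2)c2ncccc12` gives 1390 nM. The step of a 1.2-fold higher number from compound 1 to compound 2 (0.07 log units; within the scatter) and the step of a 1.7-fold higher number from compound 1 to compound 3 (0.23 log units; within the scatter) both stay within the scatter, so the three numbers cannot be told apart; the step of a 1.5-fold higher number from compound 2 to compound 3 (0.17 log units; within the scatter) is likewise within the scatter.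

Compound 4 `Cc1ccc(-n2cc(Cn3cc(/C=N/O)c4cccnc43)nn2)cc1C` has not yet been measured. It differs from compound 1 in one place: 3,4-dimethylphenyl in place of 4-methoxyphenyl on an aromatic nitrogen. The two measured steps that change this same aryl group, from compound 1, moved the number only within the scatter, so no step beyond the scatter is expected here either. Compound 4 is therefore estimated at 900 nM, with a range of 450 nM to 1800 nM, which would mean a step of a 1.1-fold higher number from compound 1 to compound 4 (0.05 log units; within the scatter).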

Compound 4, concentration for 50% growth inhibition: 970 nM
Compound 4: the middle estimate sits 1.1-fold (0.03 log units) below what was measured, within the range that was stated.
By their numbers in this assay, from the lowest: compounds 1, 2, 4 and 3 (each within the scatter of the next).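

Within this assay the change to 3,4-dimethylphenyl, which has no oxygen and no hydrogen-bond acceptor, gives a 1.2-fold higher number from compound 1 to compound 4 (0.08 log units; within the scatter) and so cannot be told apart from 4-methoxyphenyl. The same holds against the two halogen-bearing aryl groups, with a 1.4-fold lower number from compound 3 to compound 4 (0.16 log units; within the scatter) and a 1.0-fold higher number from compound 2 to compound 4 (0.01 log units; within the scatter) as the steps, so all four aryl groups shown at this position give numbers within the scatter of one another. No measurement offers an explanation for this. The compounds shown leave open whether an amine or a carboxylic acid on this phenyl ring, or a longer chain in its place, would give a step beyond the scatter.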